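The source may hold more compounds than are shown below. What is called first, only, known or untested is meant among the compounds shown, and "the series" means these compounds.

Within the data shown here, compound 1 `CCCn1c(=O)c2nc(-c3cnn(Cc4cccc(C)c4)c3)[nH]c2n(CCC)c1=O` is the one compound here with a measured number. In an assay on CHO cells for displacement of a labelled ligand from adenosine receptor A1 (Homo sapiens) (on this read-out higher numbers stand for weaker inhibition and lower numbers for stronger inhibition), compound 1 gives 48 nM. Compound 2 `CCCn1c(=O)c2nc(-c3cnn(Cc4ccc(OC)c(C(F)(F)F)c4)c3)[nH]c2n(CCC)c1=O`, a close relative carrying a methoxy and a trifluoromethyl group on its benzyl ring, has no result in this assay: compound 2 is recorded as "not determined" (no result reported). So compound 1 stands alone on the numbers, with nothing to compare it against among the measured compounds.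

The step to compound 3 `CCCn1c(=O)c2nc(-c3cnn(Cc4ccccc4C)c3)[nH]c2n(CCC)c1=O` moves the methyl group around the benzyl ring: 2-methylphenyl in place of 3-methylphenyl on a saturated chain carbon bound to an aromatic nitrogen. The two compounds share every atom and differ only in where that methyl sits.

Among the measured compounds shown here, with no measured pair showing what such a move does, the size of the step can only be guessed. A shift of a single methyl within an aromatic ring tends to matter little, so the expectation is a step from compound 1 to compound 3 of roughly a 1.7-fold higher number from compound 1 to compound 3 (0.22 log units; within the scatter), toward weaker binding but close to the scatter of repeated measurements. On that basis compound 3 is estimated to give 80 nM in this assay, with a range from 25 nM to 300 nM.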

Compound 3, inhibition constant: 22 nM
Beside the measured number, compound 3's estimate is 3.6-fold (0.56 log units) above it; measured number outside the range, below it.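

Moving the methyl group around the benzyl ring, with every atom kept, gives a 2.2-fold lower number from compound 1 to compound 3 (0.34 log units; beyond the scatter) in this assay, a modest step toward stronger inhibition that lies beyond the scatter of repeated measurements. Among these compounds, this is the first comparison available for the aryl group on a saturated chain carbon bound to an aromatic nitrogen, and it shows that the read-out responds to where a single methyl sits on that ring, even when the group's size and atom count stay the same. The compounds give no explanation for the change from 3-methylphenyl to 2-methylphenyl.

One pair of compounds cannot show whether the gain belongs to the methyl group itself or would appear with other groups in its place, such as an ethyl group, a chlorine atom or a methoxy group. Also open, on these data alone, is how a larger change would read at this position, for example an amine or a carboxylic acid on the ring, and whether the same methyl move would have a similar effect on a different core.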